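The source may hold more compounds than are shown below. What is called first, only, known or untested is meant among the compounds shown, and "the series" means these compounds.

Measured so far:
compound 1 `CC1(C)N=C(N)N=C(N)N1c1ccc(CCCCc2ccc(Cl)cc2Cl)cc1` gives 7.92 in an assay on isolated protein for inhibition of Dihydrofolate reductase (Mus musculus); on this read-out higher numbers stand for higher potency (the scale is a negative logarithm) and lower numbers for lower potency
compound 2 `CC1(C)N=C(N)N=C(N)N1c1cccc(CCCCc2ccc(Cl)cc2Cl)c1` gives 8.03 in this assay

Of the compounds shown here, two of the same core have been measured. In this assay compound 1 stands with 7.92, and compound 2 stands within the usual scatter of it at 8.03; the two numbers show no difference worth reading. Compound 3 `CC1(C)N=C(N)N=C(N)N1c1ccc(CCCCc2ccc(S(=O)(=O)F)cc2Cl)cc1` has not yet been measured. It differs from compound 1 in one place: fluorosulfonyl in place of chloro on an aromatic carbon. Among the compounds with values here, no step between measured compounds is available to guide the expectation, so only a small step, if any, is foreseen. The step from compound 1 to compound 3 is estimated at a number 0.18 log units higher from compound 1 to compound 3 (within the scatter), not beyond the scatter. Compound 3 is therefore expected to give about 8.1, likely between 7.4 and 8.8.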

Compound 3, logarithm of the reciprocal of the active concentration, log(1/C): 7.96
Beside the measured number, compound 3's estimate is 0.14 log units above it; the measured number falls inside the stated range.
By their numbers in this assay, from the lowest: compounds 1, 3 and 2 (each within the scatter of the next).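

In this assay, fluorosulfonyl in place of chloro on an aromatic carbon, para to a large group and meta to a chloro group, gives a number 0.04 log units higher from compound 1 to compound 3 (within the scatter) and so no difference worth reading. At this position, a group of 4 heavy atoms with 2 hydrogen-bond acceptors therefore reads the same as a single chlorine. On these data alone, whether an amine or a carboxylic acid at this place would also read the same stays open, as does the effect of fluorosulfonyl in place of the other chloro group. Nothing measured here speaks to why the two compounds read alike.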